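This account rests on a few compounds, and the source may have more. Where it says the series, first, only, none or still open, it means among the compounds named here.

Among the compounds with values here, in a physicochemical assay for lipophilicity (on this read-out lower numbers stand for lower lipophilicity and higher numbers for higher lipophilicity), only two compounds have numbers so far. Compound 1 `Fc1cccnc1Nc1ncc(-c2cnc3ccc(N[C@H]4CCNC4)nn23)cn1` gives 0.4, and compound 2 `CN1CC[C@H](Nc2ccc3ncc(-c4cnc(Nc5ncccc5F)nc4)n3n2)C1` gives 1.5, the higher of the two. They differ in one place, methyl in place of hydrogen on an amine nitrogen in a ring, and the measured step is a number 1.10 log units higher from compound 1 to compound 2 (beyond the scatter).

The next structure, compound 3 `CN1CC[C@H](Oc2ccc3ncc(-c4cnc(Nc5ncccc5F)nc4)n3n2)C1`, keeps that methyl and changes a different place: (1-methylpyrrolidin-3-yl)oxy in place of (1-methylpyrrolidin-3-yl)amino on an aromatic carbon. Put simply, (1-methylpyrrolidin-3-yl)oxy stands in place of (1-methylpyrrolidin-3-yl)amino on an aromatic carbon. The swap leaves the ring and the atom count of the group as they were, but the hydrogen-bond donor count changes.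

Within the data shown here, no measured pair tests this swap. Among the measured compounds shown here, the one available step, a number 1.10 log units higher from compound 1 to compound 2 (beyond the scatter), shows only how far a single small edit can move this assay, and it was made elsewhere in the molecule. A smaller upward move is therefore expected, and a result within the scatter would be no surprise. The expected change is a number 0.30 log units higher from compound 2 to compound 3 (within the scatter). For compound 3 the estimate is 1.8, with an expected range from 1.3 to 2.4.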

Compound 3, distribution coefficient: 1.5
For compound 3 the middle estimate is 0.30 log units above the measured one, and the stated range covers the measured number.
By their numbers in this assay, from the lowest: compound 1; then compounds 2 and 3 (each within the scatter of the next).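

In this assay, within the data shown here, the earlier compounds showed only what a methyl on the ring nitrogen does, while this pair is the first test of the atom that links the pyrrolidine ring to the aromatic carbon. Putting (1-methylpyrrolidin-3-yl)oxy in place of (1-methylpyrrolidin-3-yl)amino gives no change at the digits printed from compound 2 to compound 3 (within the scatter) even though the group goes from 1 hydrogen-bond donor to 0, so at this position, in this one pair, removing that donor leaves the read-out unmoved. The step that combines both edits, a number 1.10 log units higher from compound 1 to compound 3 (beyond the scatter), is the same size as the methyl step alone, a number 1.10 log units higher from compound 1 to compound 2 (beyond the scatter), and no measured evidence is available to explain why the linking atom makes no visible difference here.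

From the compounds shown here alone, it remains open whether a sulfur atom or a methylene group as the link would also leave the number in place, since this position has been read with only the amino and oxy links. Also open, going by these compounds, is how (pyrrolidin-3-yl)oxy, with a hydrogen on the ring nitrogen, would compare, which would show whether the methyl step carries over to the oxygen-linked series.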